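Cyano in place of trifluoromethyl: working notes on compound 3

The source may hold more compounds than are shown below. What is called first, only, known or untested is meant among the compounds shown, and "the series" means these compounds.

Values so far in a functional assay on QGY-7703 cells (Homo sapiens) for cytotoxicity, read by MTT assay, with a stated time of 24 h (on this read-out lower numbers stand for stronger inhibition and higher numbers for weaker inhibition), are these.
- compound 1 (`O=C1/C(=C/c2cccnc2)CN(S(=O)(=O)c2ccc([N+](=O)[O-])cc2)C/C1=C\c1ccccc1F`) gives 5600 nM as its value
- compound 2 (`O=C1/C(=C/c2cccnc2)CN(S(=O)(=O)c2ccc(C(F)(F)F)cc2)C/C1=C\c1ccccc1F`) gives 4500 nM as its value

Compound 2 and compound 1 lie within the scatter of each other, so neither stands apart on these numbers. Next comes compound 3 (`N#Cc1ccc(S(=O)(=O)N2C/C(=C\c3cccnc3)C(=O)/C(=C/c3ccccc3F)C2)cc1`), which carries cyano in place of trifluoromethyl on an aromatic carbon, para to a large group (cyano in place of trifluoromethyl on an aromatic carbon). For the measured compounds named here, one measured step bears on this exchange, made on the same aromatic carbon (a 1.2-fold lower number from compound 1 to compound 2 (0.09 log units; within the scatter)), and it stayed within the scatter. Going by the values given here, no measured compound yet carries cyano there. Among the compounds with values here, with only that step (a 1.2-fold lower number from compound 1 to compound 2 (0.09 log units; within the scatter)) to go on, no change beyond the scatter is expected in this assay in either direction. The expected step is small (a 1.1-fold higher number from compound 2 to compound 3 (0.03 log units; within the scatter)). For compound 3 the estimated value is 4800 nM with an expected range (2400 nM to 9500 nM).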

Compound 3, half-maximal inhibitory concentration: 15800 nM
Compound 3: the middle estimate sits 3.3-fold (0.52 log units) below what was measured, and the stated range ends below it.
By their numbers in this assay, from the lowest: compounds 2 and 1 (each within the scatter of the next); then compound 3.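

In this assay, the aromatic carbon para to a large group proves sensitive to the choice of group: cyano gives weaker inhibition than trifluoromethyl (a 3.5-fold higher number from compound 2 to compound 3 (0.55 log units; beyond the scatter)) and than nitro (a 2.8-fold higher number from compound 1 to compound 3 (0.45 log units; beyond the scatter)), whereas the earlier exchange between nitro and trifluoromethyl showed no separation beyond the scatter. Among the three groups shown at this carbon, cyano alone stands apart, and both steps are modest in size. No available evidence accounts for this difference.

For the compounds shown here, whether the weaker inhibition is particular to cyano remains open, as only three groups at this carbon can be compared. An amine or a methoxy group at the same carbon would show whether trifluoromethyl and nitro or cyano better represents the wider range of groups tolerated there.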